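Methylating the Amide Nitrogen of Compound 3

The source may hold more compounds than are shown below. What is called first, only, known or untested is meant among the compounds shown, and "the series" means these compounds.

Compound 3 `O=C(NCCCCc1ccccc1)c1ccc[nH]1` was tested in an assay on mitochondria for inhibition of Amine oxidase [flavin-containing] A (Bos taurus), read by fluorescence; on this read-out lower numbers stand for stronger inhibition and higher numbers for weaker inhibition. In this assay, among the measured compounds shown here, compound 3 gives 55 nM, the second highest of the three numbers measured so far. Compound 1 `C#CCN(C)Cc1ccc[nH]1` gives 5.4 nM, a lower number beyond the scatter, while compound 2 `CN(Cc1ccccc1)Cc1ccc[nH]1` gives 3500 nM, a higher number beyond the scatter. Compound 4 `CN(CCCCc1ccccc1)C(=O)c1ccc[nH]1` has not yet been measured. It differs from compound 3 in one place: methyl in place of hydrogen on an amide-type nitrogen. No two measured compounds differ in exactly this way, so the effect cannot be read off from the numbers shown. A modest step toward a higher number is expected, estimated as a 2.7-fold higher number from compound 3 to compound 4 (0.44 log units; beyond the scatter). Compound 4 is therefore estimated at 150 nM, within a range from 40 nM to 600 nM.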

Compound 4, inhibition constant: 90 nM
Estimate against measurement, compound 4: 1.7-fold (0.22 log units) above, and the stated range covers the measured number.
By their numbers in this assay, from the lowest: compound 1; then compounds 3 and 4 (each within the scatter of the next); then compound 2.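

In this assay methyl in place of hydrogen on an amide-type nitrogen gives a 1.6-fold higher number from compound 3 to compound 4 (0.21 log units; within the scatter) and so leaves the two compounds indistinguishable. Among the compounds shown here, for this pair, then, the amide hydrogen can be replaced by methyl with no change beyond the scatter, something the earlier compounds could not show. No measurement here offers an explanation for this result.

As far as these compounds go, whether an ethyl group or a benzyl group on this same nitrogen would also leave the number within the scatter remains open. So does the effect of a shorter or longer chain between this nitrogen and the phenyl ring.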